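The source may report more compounds than this note shows. Statements on the series, on what has been measured and on what is new or still open speak of the compounds shown alone.

In a functional assay on HT-29 cells (Homo sapiens) for cytotoxicity, read by MTT assay, with a stated time of 6 days (on this read-out higher numbers stand for an effect only at larger amounts of compound and lower numbers for an effect already at smaller amounts), compound 1 `COC(=O)c1c(-c2ccc(Br)cc2)oc2ccccc2c1=O` gives > 25 ug/mL, which is a limit and not a number. Compound 2 `COC(=O)c1c(-c2ccc([N+](=O)[O-])cc2)oc2ccccc2c1=O` gives > 25 ug/mL, also a limit, so it has no exact position on this scale. The evidence so far is the limit of > 25 ug/mL in this assay, at which 2 of the 2 values shown sit. Going by the values given here, the only measured step is a step that the two limits leave unreadable from compound 1 to compound 2, so it offers no size to carry forward. Compound 3 `COC(=O)c1c(-c2ccc([N+](=O)[O-])cc2)oc2cc(OC)ccc2c1=O` has methoxy in place of hydrogen on an aromatic carbon of compound 2 (methoxy in place of hydrogen on an aromatic carbon). No direction can be expected from these data, and the estimated step is a step that the limit leaves unreadable from compound 2 to compound 3, which is not expected to exceed the scatter. Compound 3 is estimated at 30 ug/mL, within an expected range of 12 ug/mL to 60 ug/mL.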

Compound 3, concentration for half-maximal effect: > 25 ug/mL
Compound 3: a limit, no number; the forecaster's own chance of this, stated with the estimate: 70%; the middle value does not contradict the limit.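

Compound 2 and compound 3 both give a limit rather than a number, so no step can be read between them. The compounds shown leave open where any of them would fall on the scale of this assay.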